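Dropping a chloro from a dichloropurine: what to expect

The source may hold more compounds than are shown below. What is called first, only, known or untested is meant among the compounds shown, and "the series" means these compounds.

Of the compounds shown here, two have been measured in a functional assay on OVCAR-4 cells (Homo sapiens) for cytotoxicity, read by sulforhodamine B assay, with a stated time of 48 h; a lower number here means a stronger inhibitor of growth, a higher number a weaker inhibitor of growth. Compound 2, with the structure `ClCc1ccccc1Cn1cnc2c(Cl)nc(Cl)nc21`, gives 3630 nM in this assay. Compound 1, with the structure `ClCc1ccc(Cn2cnc3c(Cl)ncnc32)cc1`, gives 6600 nM in this assay. Compound 2 has the lower of these two numbers, but the gap to compound 1 is within the usual scatter of repeated measurements, so the two compounds cannot be told apart on this evidence. Compound 1 and compound 2 also differ in more than one place, so no single structural change can be read from their pair.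

Compound 3, with the structure `ClCc1ccccc1Cn1cnc2c(Cl)ncnc21`, has not yet been measured. It is derived from compound 2 by a single change: hydrogen in place of chloro on an aromatic carbon. Among the compounds with values here, no measured pair shows this change on its own, so the size of the step is unknown. Given that compound 1, which also carries hydrogen at this position, gives 6600 nM, the expected step from compound 2 to compound 3 is a 1.4-fold higher number from compound 2 to compound 3 (0.14 log units; within the scatter), a change that may well stay within the scatter. Compound 3 is therefore estimated at 5000 nM, with a range from 1800 nM to 14000 nM.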

Compound 3, concentration for total growth inhibition: 12300 nM
Beside the measured number, compound 3's estimate is 2.5-fold (0.39 log units) below it; measured number inside the range.
By their numbers in this assay, from the lowest: compounds 2, 1 and 3 (each within the scatter of the next, the first and the last beyond it).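

In this assay, putting hydrogen in place of chloro on the aromatic carbon between two ring nitrogen atoms gives a 3.4-fold higher number from compound 2 to compound 3 (0.53 log units; beyond the scatter). Within the data shown here, this is the first step in which this position changes and nothing else does, so the difference can be tied to this one change, and it lies beyond the usual scatter. The chloro here is therefore not a silent passenger: losing this single heavy atom gives a modest but readable loss of growth inhibition, though no measurement shown here explains why the step occurs.

Among the compounds shown, this position carries only chloro or hydrogen, so it remains open what an amine, a methoxy group or a thiol would do there, and whether the effect follows from the chloro itself or would appear with any group larger than hydrogen. Compound 1 has no chloro partner among the compounds shown, so it also remains open whether the step would have a similar size with the chloromethyl group placed as it is in compound 1.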